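The compounds below may be only part of what the source reports. "The series", "measured", "known", "first", "only" and "open" are said of these compounds alone.

In a functional assay on HL-60 cells (Homo sapiens) for antiproliferative activity, read by XTT assay, with a stated time of 72 h (on this read-out higher numbers stand for weaker inhibition and lower numbers for stronger inhibition), compound 1 `Cc1ncnc2c1c(-c1ccsc1)cn2[C@@H]1O[C@H](CO)[C@@H](O)[C@H]1O` gives 350 nM, a measured potency that serves as a point of reference. Compound 2 `Nc1nc2c(c(-c3ccoc3)cn2[C@@H]2O[C@H](CO)[C@@H](O)[C@H]2O)c(=O)[nH]1` has a different core and carries a furan-3-yl group, and in this assay compound 2 reads > 15000 nM. That reading is a limit of the assay and not a number. Compound 2 therefore stands at the limit of > 15000 nM in this assay, at which 1 of the 2 values shown sits.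

Compound 3 `Nc1nc2c(c(-c3ccccc3)cn2[C@@H]2O[C@H](CO)[C@@H](O)[C@H]2O)c(=O)[nH]1` keeps the rest of compound 2 and makes a single change, phenyl in place of furan-3-yl on an aromatic carbon. Among the compounds with values here, no measured pair here shows what such a swap does, and compound 1 differs from compound 2 in more than one place, so it offers no direct guide.

The expectation rests on compound 2 at > 15000 nM, which is a limit. No step beyond the usual scatter is expected in this assay, in either direction, and the result may again be only a limit. The expected change is small, with an estimated step that the limit leaves unreadable from compound 2 to compound 3. For compound 3 the estimate is 20000 nM, with an expected range from 6000 nM to 60000 nM.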

Compound 3, half-maximal inhibitory concentration: > 20000 nM
Compound 3: only a limit was reported (the forecaster's own chance of this, stated with the estimate: 70%); the middle value sits exactly at the limit.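

In this assay, compound 2 and compound 3 each gave only a limit of the assay and not a number, so no step can be read between them. The compounds shown leave open how strongly either one acts on these cells, and whether phenyl in place of furan-3-yl changes that at all.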